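The source may report more compounds than this note shows. Statements on the series, on what has been measured and on what is new or still open speak of the compounds shown alone.

Measured in a functional assay on A549 cells (Homo sapiens) for cytotoxicity, read by MTT assay, with stated times of 48 h and 4 h; on this read-out lower numbers stand for stronger inhibition and higher numbers for weaker inhibition:
- Compound 1 `COc1ccc(/C=C/c2nc(NCCN3CCCCC3)c3cc(Cl)ccc3n2)cc1OC`: > 100000 nM
- Compound 2 `NCCCCNc1nc(/C=C/c2ccc([N+](=O)[O-])cc2)nc2ccccc12`: 5480 nM
- Compound 3 `O=[N+]([O-])c1ccc(/C=C/c2nc(NCCN3CCCCC3)c3cc(Cl)ccc3n2)cc1`: 41100 nM

The entry for compound 1 is a limit and not a number: the limit of > 100000 nM in this assay, at which 1 of the 3 values shown sits. Compound 3, at 41100 nM, holds the higher of the two actual numbers, and compound 2 lies lower at 5480 nM.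

Compound 4 `NCCCCNc1nc(/C=C/c2ccc([N+](=O)[O-])cc2)nc2ccc(Cl)cc12` is the next case. The change from compound 3 is 2-aminoethyl in place of piperidin-1-yl on a saturated chain carbon, two bonds along the chain from a nitrogen on an aromatic ring. Cut further out, (4-aminobutyl)amino replaces (2-(piperidin-1-yl)ethyl)amino.

Among the compounds with values here, the only measured step, an at least 2.4-fold lower number from compound 1 to compound 3 (0.38 log units; beyond the scatter), lies at a different place and starts from a limit, so it gives no size for this change. The closest guide is compound 2, which also carries (4-aminobutyl)amino and gives 5480 nM. On that basis, a move to a lower number in this assay, beyond the scatter, is expected: a 6.9-fold lower number from compound 3 to compound 4 (0.84 log units; beyond the scatter). For compound 4 the estimated value is 6000 nM, with an expected range of 1800 nM to 20000 nM.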

Compound 4, half-maximal inhibitory concentration: 10000 nM
For compound 4 the middle estimate is 1.7-fold (0.22 log units) below the measured one; the range from low to high includes it.
By their numbers in this assay, from the lowest: compounds 2 and 4 (each within the scatter of the next); then compound 3. At a limit, above all of these: compound 1.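

Within the data shown here, replacing (2-(piperidin-1-yl)ethyl)amino with (4-aminobutyl)amino while the chloro group stays in place gives a 4.1-fold lower number from compound 3 to compound 4 (0.61 log units; beyond the scatter) in this assay, the first step at this position that starts from a number and not a limit. With (4-aminobutyl)amino held fixed, chloro in place of hydrogen on an aromatic carbon gives a 1.8-fold higher number from compound 2 to compound 4 (0.26 log units; within the scatter), so compound 2 and compound 4 cannot be ordered and no effect of chloro can be read from this pair. No measured property shown bears on the cause of either step.

The compounds shown do not separate the contribution of the terminal primary amine from that of the piperidine ring or the chain length. A (4-(piperidin-1-yl)butyl)amino or a shorter (2-aminoethyl)amino side chain on the same core would help to tell these apart.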